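Working notes: from compound 2 to compound 3

The source may report more compounds than this note shows. Statements on the series, on what has been measured and on what is new or still open speak of the compounds shown alone.

Measured in a functional assay on HT-29 cells (Homo sapiens); on this read-out lower numbers stand for stronger inhibition of growth and higher numbers for weaker inhibition of growth:
- compound 1 `O=S(=O)(/C=C/c1ccccc1)Cc1ccc(Nc2ncnc3ccccc23)cc1`: > 100000 nM
- compound 2 `O=S(=O)(/C=C/c1ccc(Br)cc1)Cc1ccc(Nc2ncnc3ccccc23)cc1`: > 100000 nM

Neither entry is a number. Compound 2 stands at a limit, > 100000 nM, and so does compound 1 in its own entry. For the measured compounds named here, the series so far sits entirely at the limit of > 100000 nM in this assay, at which 2 of the 2 values shown sit.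

The next compound is compound 3 `O=S(=O)(/C=C/c1ccc(F)cc1F)Cc1ccc(Nc2ncnc3ccccc23)cc1`. The change from compound 2 is 2,4-difluorophenyl in place of 4-bromophenyl on a double-bonded chain carbon bound to a double-bonded chain carbon. Cut one bond further out, the same difference reads 2-(4-bromophenyl)ethenyl to 2-(2,4-difluorophenyl)ethenyl.

Going by the values given here, one measured step bears on a change on this aromatic ring: a step that the two limits leave unreadable from compound 1 to compound 2. It has no readable size, so there is no measured size to carry over to the new change. With nothing pointing either way, no step beyond the scatter is expected in this assay. The expectation rests on compound 2 at > 100000 nM, which is a limit. The expected step is a number no higher from compound 2 to compound 3 (the limit leaves the size open). For compound 3 the estimated value is 100000 nM, with an expected range of 30000 nM to 200000 nM.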

Compound 3, concentration for 50% growth inhibition: > 100000 nM
Compound 3 gave a limit, no number (the forecaster's own chance of this, stated with the estimate: 70%); the middle value sits exactly at the limit.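

In this assay compound 3 gives > 100000 nM, a limit and not a number. For the compounds shown here, the steps from compound 1 and from compound 2 to compound 3 cannot be read, so no new step comes from this result. The compounds shown leave open whether any change on this aromatic ring alters growth inhibition, as the series rests on one entry: the limit of > 100000 nM in this assay, at which 3 of the 3 values shown sit.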